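The source may hold more compounds than are shown below. What is called first, only, known or untested is meant among the compounds shown, and "the series" means these compounds.

Compound 1 `Fc1ccc2nc(-c3cccnc3)[nH]c2c1`: 1990 nM
Compound 2 `Fc1cccc2c1nc(-c1cccnc1)n2C1CC1`: > 8330 nM

Compound 1 is the only one of the two with a number in an assay on V79 cells for inhibition of cytochrome P450 11B1, mitochondrial (Homo sapiens), read by HTRF, with a stated time of 1 h (a lower number here means a stronger inhibitor, a higher number a weaker inhibitor), where compound 1 gives 1990 nM. Compound 2 reaches only a limit of that assay, > 8330 nM. Compound 3 `CC(C)(C)n1c(-c2cccnc2)nc2ccc(F)cc21` is not yet measured; it differs from compound 1 by tert-butyl in place of hydrogen on an aromatic nitrogen. Among the compounds with values here, no step between two measured compounds is available to lean on, so the expected step from compound 1 to compound 3 is a 3.0-fold higher number from compound 1 to compound 3 (0.48 log units; beyond the scatter), toward weaker inhibition, beyond the scatter. Compound 3 is estimated at 6000 nM, within 2000 nM to 20000 nM. A limit instead of a number is also plausible, since the limit of > 8330 nM in this assay, at which 1 of the 2 values shown sits, already holds one of the two readings.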

Compound 3, half-maximal inhibitory concentration: > 10000 nM
Compound 3: only a limit was reported (the forecaster's own chance of this, stated with the estimate: 40%); middle value at least 1.6-fold (0.22 log units) from the limit.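

In this assay, within the data shown here, tert-butyl in place of hydrogen on the aromatic nitrogen gives an at least 5.0-fold higher number from compound 1 to compound 3 (0.70 log units; beyond the scatter), the first step that can be read at this position, and it runs toward weaker inhibition. Compound 3 reaches only a limit, so the step has a lower bound but no known full size: the limit of > 10000 nM in this assay, at which 1 of the 3 values shown sits.

From the compounds shown here alone, with a single replacement of this hydrogen to read, it remains open whether tert-butyl specifically or any added group weakens inhibition here. A methyl or a short chain ending in an amine on this nitrogen could separate those two readings.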